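Replacing the hydroxyphenyl group with a phenylethenyl group

The source may hold more compounds than are shown below. What is called first, only, known or untested is meant among the compounds shown, and "the series" means these compounds.

Compound 3 `CCCCCCCCS(=O)(=O)Nc1ccc(-c2ccc(O)cc2)cc1C(=O)O` gives 47300 nM in an assay on mitochondria (strain BALB/c) for inhibition of glycerol-3-phosphate acyltransferase 1, mitochondrial (Mus musculus), read by scintillation counting, with a stated time of 10 min (on this read-out higher numbers stand for weaker inhibition and lower numbers for stronger inhibition), the second highest of the three numbers measured. Compound 1 `CCCCCCCCS(=O)(=O)Nc1ccc(-c2ccc(Cl)cc2)cc1C(=O)O` gives 9200 nM, and compound 2 `CCCCCCCCS(=O)(=O)Nc1ccc(-c2ccccc2O)cc1C(=O)O` gives 61700 nM. The step of a 1.3-fold lower number from compound 2 to compound 3 (0.12 log units; within the scatter) lies within the scatter, whereas a 5.1-fold higher number from compound 1 to compound 3 (0.71 log units; beyond the scatter) lies beyond it. Compound 4 `CCCCCCCCS(=O)(=O)Nc1ccc(/C=C/c2ccccc2)cc1C(=O)O` carries 2-phenylethenyl in place of 4-hydroxyphenyl on an aromatic carbon. Within the data shown here, the hydroxy group is thereby removed, so the step that bears most on this change is a 5.1-fold higher number from compound 1 to compound 3 (0.71 log units; beyond the scatter), which a return to a group without a donor or acceptor would tend to reverse; no measured step covers the entry of the phenylethenyl group itself. Compound 4 is therefore expected to give 12000 nM, with a range from 4000 nM to 36000 nM, an estimated step of a 3.9-fold lower number from compound 3 to compound 4 (0.60 log units; beyond the scatter).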

Compound 4, half-maximal inhibitory concentration: 16300 nM
The estimate for compound 4 lay 1.4-fold (0.13 log units) below the measured number, and the stated range covers the measured number.
By their numbers in this assay, from the lowest: compounds 1 and 4 (each within the scatter of the next); then compounds 3 and 2 (each within the scatter of the next).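

Putting 2-phenylethenyl in place of 4-hydroxyphenyl gives a 2.9-fold lower number from compound 3 to compound 4 (0.46 log units; beyond the scatter) and in place of 2-hydroxyphenyl gives a 3.8-fold lower number from compound 2 to compound 4 (0.58 log units; beyond the scatter) at this position. Set against 4-chlorophenyl the same group gives a 1.8-fold higher number from compound 1 to compound 4 (0.25 log units; within the scatter) so the position takes a double bond outside the aromatic rings with the number staying level with that of compound 1. Nothing given here accounts for these differences. Still open, on these data alone, is whether a plain phenyl group or a saturated ethyl link would match compound 4, and whether an amine would behave as the hydroxy group does.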